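The source may hold more compounds than are shown below. What is called first, only, known or untested is meant among the compounds shown, and "the series" means these compounds.

Working notes on the series.

Going by the values given here, in an assay on Sf21 cells for inhibition of ubiquitin carboxyl-terminal hydrolase 7 (Homo sapiens), read by spectrophotometry, with stated times of 30 min and 2 h (on this read-out lower numbers stand for stronger inhibition and higher numbers for weaker inhibition), compound 1 `O=c1c2cnn(-c3ccc(F)cc3)c2ncn1CC1(O)CCN(Cc2ccccc2F)CC1` gives 9800 nM, the highest of the three numbers so far. Compound 2 `O=c1c2cnn(-c3ccc(F)cc3)c2ncn1CC1(O)CCN(Cc2ccccc2Cl)CC1` gives 3400 nM and compound 3 `O=c1c2cnn(-c3ccc(F)cc3)c2ncn1CC1(O)CCN(Cc2ccc(Br)cc2Cl)CC1` gives 1900 nM in this assay.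

Compound 4 `COC(=O)c1ccc(CN2CCC(O)(Cn3cnc4c(cnn4-c4ccc(F)cc4)c3=O)CC2)c(Cl)c1` differs from compound 1 by 2-chloro-4-(methoxycarbonyl)phenyl in place of 2-fluorophenyl on a saturated chain carbon bound to an amine nitrogen in a ring. Among the compounds with values here, two measured steps bear on it. The step of a 2.9-fold lower number from compound 1 to compound 2 (0.46 log units; beyond the scatter) shows that chloro in place of fluoro on the aromatic carbon already moves the number beyond the scatter. The step of a 5.2-fold lower number from compound 1 to compound 3 (0.71 log units; beyond the scatter) carries the same chloro together with bromo, and a 1.8-fold lower number from compound 2 to compound 3 (0.25 log units; within the scatter) shows the added bromo alone stays within the scatter. Within the data shown here, compound 4 keeps the chloro of compounds 2 and 3 and carries a methoxycarbonyl where compound 3 carries bromo; no measured step covers a methoxycarbonyl at that place.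

The expected step is therefore of the size seen for compound 2 and compound 3, a 3.9-fold lower number from compound 1 to compound 4 (0.59 log units; beyond the scatter), a lower number in this assay. Compound 4 is expected to give 2500 nM in this assay, with a range of 1000 nM to 7000 nM.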

Compound 4, half-maximal inhibitory concentration: 800 nM
The estimate for compound 4 lay 3.1-fold (0.49 log units) above the measured number; measured number below the stated range.
By their numbers in this assay, from the lowest: compound 4; then compounds 3 and 2 (each within the scatter of the next); then compound 1.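

Going by these compounds alone, the change at this place reaches further than the earlier compounds showed: on a saturated chain carbon bound to an amine nitrogen in a ring, 2-chloro-4-(methoxycarbonyl)phenyl in place of 2-fluorophenyl gives a 12-fold lower number from compound 1 to compound 4 (1.09 log units; beyond the scatter) in this assay. Bromo in place of hydrogen on the aromatic carbon stayed within the scatter with a 1.8-fold lower number from compound 2 to compound 3 (0.25 log units; within the scatter), but that carbon does respond to substitution, since methoxycarbonyl in place of hydrogen gives a 4.3-fold lower number from compound 2 to compound 4 (0.63 log units; beyond the scatter) and methoxycarbonyl in place of bromo gives a 2.4-fold lower number from compound 3 to compound 4 (0.38 log units; beyond the scatter). No measurement in hand offers an explanation for these steps.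

The compounds shown leave open whether a carboxylic acid or a primary amide on the same aromatic carbon would give a similar number. They also leave open whether the methoxycarbonyl step would hold with fluoro or hydrogen in place of chloro.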